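This account rests on a few compounds, and the source may have more. Where it says the series, first, only, none or still open, it means among the compounds named here.

Three compounds have been measured in a functional assay on SW-620 cells (Homo sapiens) for cytotoxicity, read by MTT assay, with a stated time of 72 h; on this read-out lower numbers stand for stronger inhibition and higher numbers for weaker inhibition:

compound 1, `COc1cccc(/C=C2\CCC/C(=C\c3cccc(Br)c3)C2=O)c1OC`, 8800 nM
compound 2, `COc1cccc(/C=C2\CCC/C(=C\c3ccc(Cl)cc3Cl)C2=O)c1OC`, 16300 nM
compound 3, `COc1ccc(/C=C2\CCC/C(=C\c3ccccc3Br)C2=O)cc1OC`, 5300 nM

Compound 3 gives the lowest of the three numbers. Its nearest neighbour is compound 1, whose value sits within the scatter of that of compound 3, so no order between these two can be read from the numbers. Compound 2 lies furthest away, beyond the scatter, so compound 3 inhibits more strongly than compound 2 in this assay.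

The next compound, compound 4, `COc1cc(/C=C2\CCC/C(=C\c3ccc(OC)c(OC)c3)C2=O)ccc1O`, differs from compound 3 by one exchange: 4-hydroxy-3-methoxyphenyl in place of 2-bromophenyl on a double-bonded chain carbon bound to a double-bonded ring carbon

Going by the values given here, only one measured step touches the same position, a 1.9-fold higher number from compound 1 to compound 2 (0.27 log units; within the scatter), and it exchanged one halogenated phenyl for another; it stayed within the scatter. Among the compounds with values here, no measured step replaces a halogenated phenyl with a hydroxy-methoxyphenyl at this place, so the present exchange has no direct precedent in the numbers. Within the data shown here, the single step that does bear on it suggests that changes at this position may be small. A step of no more than the scatter is therefore expected, a 1.3-fold higher number from compound 3 to compound 4 (0.12 log units; within the scatter), with wide uncertainty. Compound 4 is estimated at 7000 nM, within 2500 nM to 20000 nM.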

Compound 4, half-maximal inhibitory concentration: 4500 nM
Compound 4: the middle estimate sits 1.6-fold (0.19 log units) above what was measured; the range from low to high includes it.
By their numbers in this assay, from the lowest: compounds 4, 3, 1 and 2 (each within the scatter of the next, the first and the last beyond it).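

In this assay, putting 4-hydroxy-3-methoxyphenyl in place of 2-bromophenyl on a double-bonded chain carbon bound to a double-bonded ring carbon gives a 1.2-fold lower number from compound 3 to compound 4 (0.07 log units; within the scatter). The earlier step at this place, a 1.9-fold higher number from compound 1 to compound 2 (0.27 log units; within the scatter), only exchanged one halogenated phenyl for another, whereas this one removes the halogen altogether and brings in a group with 1 hydrogen-bond donor and 2 hydrogen-bond acceptors, where the group leaving has none, and still stays within the scatter. The position therefore tolerates a much larger change of group than the halogen exchange alone could show, at least for this pair, although nothing measured on these compounds accounts for that tolerance.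

The compounds shown do not tell whether the hydroxy or the methoxy of the entering group has any effect of its own, since the two enter together. Nor do they tell whether a phenyl bearing an amine or a carboxylic acid, or a longer chain in place of the phenyl, would move the number in this assay beyond the scatter.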